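The source may report more compounds than this note shows. Statements on the series, on what has been measured and on what is new or still open speak of the compounds shown alone.

Compound 1 `CS(=O)(=O)c1ccc(C(=O)NCCC(=O)N2CCCCC2)cc1[N+](=O)[O-]` was examined in an assay on isolated protein for inhibition of vitamin D3 receptor (Homo sapiens), read by fluorescence polarization; a higher number here means a weaker inhibitor, a lower number a stronger inhibitor. In this assay compound 1 gives > 60000 nM, which is a limit of the assay rather than a measured number. Compound 2 `CN(Cc1cccc(F)c1)C(=O)CN(C)C(=O)c1ccc(S(C)(=O)=O)c([N+](=O)[O-])c1` belongs to the same set. In this assay compound 2 gives > 60000 nM, again a limit and not a number. Among the values shown, compound 1 therefore stands at the limit of > 60000 nM in this assay, at which 2 of the 2 values shown sit, and the data give no ranking between the two compounds. Compound 3 `CC(C)N(C(=O)CCNC(=O)c1ccc(S(C)(=O)=O)c([N+](=O)[O-])c1)C(C)C` has not yet been measured. It differs from compound 1 by diisopropylamino in place of piperidin-1-yl on a carbonyl carbon, the same difference, cut one bond further out, reading (piperidin-1-yl)carbonyl to diisopropylcarbamoyl. For the measured compounds named here, no step between measured compounds sets a size for this change, and with compound 1 resting at a limit, the step that the limit leaves unreadable from compound 1 to compound 3 is expected to be none beyond the scatter. Compound 3 is thus estimated to sit at 90000 nM in this assay, within a range from 30000 nM to 300000 nM.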

Compound 3, half-maximal inhibitory concentration: > 60000 nM
Compound 3 was reported as a limit; the forecaster's own chance of this, stated with the estimate: 85%; the middle value is on the limit's open side.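

For the compounds shown here, compound 1 and compound 3 both rest at a limit of the assay in this assay, not at a number, so no step between them can be read. The compounds shown leave open how any of them ranks against the others: the limit of > 60000 nM in this assay, at which 3 of the 3 values shown sit.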